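A few compounds are considered here, and "the series" means these few. Any claim that something is new, unique, unknown or untested is made for them only; others in the source may bear on it.

In a functional assay on DU-145 cells (Homo sapiens) for inhibition, read by trypan blue exclusion, with a stated time of 96 h (on this read-out higher numbers stand for weaker inhibition of growth and lower numbers for stronger inhibition of growth), compound 1 `O=C(/C(=C\c1ccccc1F)S(=O)(=O)c1ccc(Br)cc1)c1ccc(Cl)cc1` gives 25000 nM while compound 2 `Cc1ccc(S/C(=C/c2ccc[nH]2)C(=O)c2ccc(Cl)cc2)cc1` gives 10000 nM and compound 3 `Cc1ccc(CS/C(=C/c2ccc(F)cc2C(F)(F)F)C(=O)c2ccc(Cl)cc2)cc1` gives 50000 nM in the same test. Compound 2 thus holds the lowest number of the three, which here means the strongest inhibition of growth, and its gaps to both other compounds lie beyond the usual scatter of repeated measurements.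

One change leads from compound 2 to the unmeasured compound 4 `COc1ccc(/C=C(/Sc2ccc(C)cc2)C(=O)c2ccc(Cl)cc2)cc1` and it is counted as 4-methoxyphenyl in place of 1H-pyrrol-2-yl on a double-bonded chain carbon bound to a double-bonded chain carbon on a double-bonded chain carbon bound to a double-bonded chain carbon. In plain terms, 4-methoxyphenyl takes the place of 1H-pyrrol-2-yl.

Going by the values given here, no two measured compounds differ in only one place, so the data give no direct measure of what such a swap does. Compound 2 at 10000 nM is the lowest so far, and compound 1 at 25000 nM and compound 3 at 50000 nM both lie higher, so a modest move to a higher number in this assay is expected, meaning slightly weaker inhibition. The estimated move is a 1.6-fold higher number from compound 2 to compound 4 (0.20 log units; within the scatter) and it is expected to stay within the scatter. For compound 4 the estimated value is 16000 nM with an expected range from 6000 nM to 45000 nM in this test.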

Compound 4, concentration for 50% growth inhibition: 1000 nM
For compound 4 the middle estimate is 16-fold (1.20 log units) above the measured one; the whole stated range lies above it.
By their numbers in this assay, from the lowest: compound 4; then compound 2; then compounds 1 and 3 (each within the scatter of the next).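

In this assay, going by these compounds alone, putting 4-methoxyphenyl in place of 1H-pyrrol-2-yl on a double-bonded chain carbon bound to a double-bonded chain carbon gives a 10-fold lower number from compound 2 to compound 4 (1.00 log units; beyond the scatter), the first single change that can be read directly in this set. This shows that the group at this position can strongly affect inhibition of growth, with the lower number going with the entering group. The swap changes several counted features at once, replacing a five-membered aromatic ring that has a hydrogen-bond donor with a six-membered aromatic ring of carbon only that has a hydrogen-bond acceptor, and nothing measured here explains the step or separates these features.

Still open, going by these compounds, is whether the methoxy group or the six-membered ring itself carries the step, which unsubstituted phenyl, 4-hydroxyphenyl or 4-(dimethylamino)phenyl at the same position could help to separate. On these data alone, compounds 1 and 3 differ from compounds 2 and 4 in more than one place, so their steps cannot be read, and whether the same swap would have a similar effect on those compounds remains unknown.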